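A Second Chloro on the Dichloroacetamide Anilide

The source may report more compounds than this note shows. Statements on the series, on what has been measured and on what is new or still open speak of the compounds shown alone.

Three anilides of dichloroacetic acid are described: compound 1 `O=C(Nc1cccc(F)c1)C(Cl)Cl`, compound 2 `O=C(Nc1cccc(Cl)c1)C(Cl)Cl` and compound 3 `O=C(Nc1cccc(Cl)c1Cl)C(Cl)Cl`. In a functional assay on A549 cells (Homo sapiens) for antiproliferative activity, read by MTT assay, with a stated time of 72 h (on this read-out higher numbers stand for weaker inhibition and lower numbers for stronger inhibition), compound 1 gives "not determined" (no result reported), and compound 3 gives "not determined" (no result reported); for these two no result was reported. In this assay, going by the values given here, compound 2 gives 14800 nM, and as the only number in the set it stands alone, neither high nor low among measured relatives. Compound 4 `O=C(Nc1cc(Cl)cc(Cl)c1)C(Cl)Cl` differs from compound 2 by chloro in place of hydrogen on an aromatic carbon. Among the compounds with values here, no pair of measured compounds shows what such a change does, so the step from compound 2 to compound 4 in this assay has no anchor; a shift no larger than the usual scatter is expected, in either direction. Compound 4 is therefore estimated at 10000 nM, with a range from 4000 nM to 30000 nM. The expected step is small: a 1.5-fold lower number from compound 2 to compound 4 (0.17 log units; within the scatter).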

Compound 4, half-maximal inhibitory concentration: 4400 nM
Compound 4: the middle estimate sits 2.3-fold (0.36 log units) above what was measured; measured number inside the range.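

In this assay, adding a second chloro on the aromatic carbon, meta to the first chloro group, gives a 3.4-fold lower number from compound 2 to compound 4 (0.53 log units; beyond the scatter) and so moves the result beyond the usual scatter, towards stronger inhibition. Going by these compounds alone, this is the first measured step in the set, and it shows that this position responds to the change. Nothing shown here explains why the number falls.

Going by these compounds, whether an amine or a carboxylic acid at this same place would also lower the number remains open. So does the effect of a methoxy group there.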